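Adding a methyl to a basic amine series: solubility expectation

The compounds below may be only part of what the source reports. "The series", "measured", "known", "first", "only" and "open" are said of these compounds alone.

Of the compounds shown here, three have been measured in a physicochemical assay for solubility, at pH 1.1; a higher number here means a more soluble compound, a lower number a less soluble compound. Compound 1 `Cc1cc(CN(CC2CCCC2)[C@@H](CC(=O)O)c2ccc(Cl)cc2)ccc1OCCN1C(=O)CCC1=O` gives 3000000 nM. Compound 2 `Cc1cc(CN(C)C(CC(=O)O)c2ccc(Cl)cc2)ccc1OCCn1c(=O)ccn(C)c1=O` gives 3000000 nM, and compound 3 `CCN(Cc1ccc(OCCn2c(=O)ccn(C)c2=O)c(C)c1)C(CC(=O)O)c1ccc(Cl)cc1` gives 3000000 nM. The difference between the core of compound 1 and the core of compound 2 is not broken down here; compound 1 stands level with both of them at the digits shown, and all three values lie within the scatter of one another, so no order among them can be read.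

From compound 2 to compound 3 the change is methyl in place of hydrogen on a saturated chain carbon bound to an amine nitrogen. That step produced no change at the digits printed from compound 2 to compound 3 (within the scatter).

Compound 4 `CCc1cc(CN(CC2CCCC2)[C@@H](CC(=O)O)c2ccc(Cl)cc2)ccc1OCCN1C(=O)CCC1=O` is not yet measured. It differs from compound 1 by methyl in place of hydrogen on a saturated chain carbon bound to an aromatic carbon. Among the compounds with values here, this is the same kind of change as the one from compound 2 to compound 3, a methyl in place of a hydrogen, but the place is not identical: in the earlier pair the saturated chain carbon is bound to an amine nitrogen, whereas in compound 4 it is bound to an aromatic carbon.

Resting on the fact that the earlier methyl-for-hydrogen step gave no change at the digits printed from compound 2 to compound 3 (within the scatter), and on compound 1 sitting at 3000000 nM, the step from compound 1 to compound 4 is expected to be a 1.2-fold lower number from compound 1 to compound 4 (0.08 log units; within the scatter). Compound 4 is therefore estimated at 2500000 nM in this assay, with a range from 1000000 nM to 3500000 nM.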

Compound 4, solubility: 3000000 nM
Beside the measured number, compound 4's estimate is 1.2-fold (0.08 log units) below it; the range from low to high includes it.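

In this assay the methyl in place of hydrogen on a saturated chain carbon bound to an aromatic carbon gave no change at the digits printed from compound 1 to compound 4 (within the scatter) and so reads the same as the earlier methyl-for-hydrogen step, which gave no change at the digits printed from compound 2 to compound 3 (within the scatter) on a different core. This shows that in these two pairs the added methyl left the printed reading unmoved on both cores, but it does not show that the change carries from one core to another as a rule, since the two pairs differ in core and also in where the methyl enters, and only these two pairs are shown. No measurement shown here offers an explanation for the reading staying level in either pair.

The compounds shown leave open whether the methyl-to-ethyl change would read the same on the core of compound 2, where that exact place has its own counterpart. They also leave open whether a longer chain such as propyl, or an amine or a carboxylic acid, on that same saturated chain carbon would keep the reading of compound 4 at 3000000 nM or move it.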